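Exchanging one amino group on compound 2

The source may report more compounds than this note shows. Statements on the series, on what has been measured and on what is new or still open speak of the compounds shown alone.

In an ADME assay on A549 cells (Homo sapiens) for cytotoxicity, read by resazurin assay, with a stated time of 48 h (on this read-out higher numbers stand for lower toxicity in this test and lower numbers for higher toxicity in this test), compound 1 `CCN(CC)c1ccc(NC(=O)c2cc(Cl)ccc2O)c(Cl)c1` gives 55500 nM, and compound 2 `O=C(Nc1ccc(NCc2ccc(O)nc2)cc1Cl)c1cc(Cl)ccc1O` gives 98500 nM. These two values lie within the usual scatter of each other, so the numbers do not separate the two compounds. Compound 3 `O=C(Nc1ccc(N(CCCO)CCCO)cc1Cl)c1cc(Cl)ccc1O` keeps the shared core and differs from compound 2 in one group on an aromatic carbon: bis(3-hydroxypropyl)amino in place of ((6-hydroxypyridin-3-yl)methyl)amino on an aromatic carbon. Among the measured compounds shown here, only one measured step bears on this change. It is a 1.8-fold higher number from compound 1 to compound 2 (0.25 log units; within the scatter), an exchange of the group at that same place, and it stays within the scatter. One step is thin evidence, but it gives no reason to expect a large shift. The expected result is a 1.3-fold lower number from compound 2 to compound 3 (0.12 log units; within the scatter), which means no step beyond the scatter in this assay. Compound 3 is estimated at 75000 nM, with an expected range from 30000 nM to 170000 nM.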

Compound 3, half-maximal cytotoxic concentration: 114000 nM
For compound 3 the middle estimate is 1.5-fold (0.18 log units) below the measured one; low and high end bracket the measured number.
By their numbers in this assay, from the lowest: compounds 1, 2 and 3 (each within the scatter of the next, the first and the last beyond it).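

Replacing ((6-hydroxypyridin-3-yl)methyl)amino, which holds an aromatic ring, with bis(3-hydroxypropyl)amino, which holds no ring but has the same number of heavy atoms, gives a 1.2-fold higher number from compound 2 to compound 3 (0.06 log units; within the scatter) in this assay and so does not separate the two groups. Among the compounds shown here, measured against diethylamino, the same new group gives a 2.1-fold higher number from compound 1 to compound 3 (0.31 log units; beyond the scatter) and this is the first step at this position to pass the scatter, though only modestly. Nothing measured here explains these numbers.

Bis(3-hydroxypropyl)amino and diethylamino differ in both chain length and the end hydroxyl groups, so the compounds shown cannot say which of the two matters. On these data alone, how this number would respond to a simple amine or a propyl chain ending in a carboxylic acid at this place also remains open.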